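Compound 3 to Compound 4: A Step Among Limits

This account rests on a few compounds, and the source may have more. Where it says the series, first, only, none or still open, it means among the compounds named here.

Measured in a functional assay on HT-29 cells (Homo sapiens) for antiproliferative activity, read by MTT assay, with a stated time of 24 h; on this read-out higher numbers stand for weaker inhibition and lower numbers for stronger inhibition:
- compound 1 `COc1ccc(/C=C/C(=O)c2ccc(OC)c3c2OC(C)(C)C=C3)c(F)c1`: > 10000 nM (a limit)
- compound 2 `COc1ccc(C(=O)/C=C/c2ccc(-n3ccnc3)cc2)c2c1C=CC(C)(C)O2`: > 6600 nM (a limit)
- compound 3 `COc1ccc(C(=O)/C=C/c2ccco2)c2c1C=CC(C)(C)O2`: > 10000 nM (a limit)

None of the three compounds has yet given a number. Compound 3 stands at the limit of > 10000 nM in this assay, at which 2 of the 3 values shown sit. Compound 2 stands at the limit of > 6600 nM in this assay, at which 1 of the 3 values shown sits.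

Compound 4 `COc1ccc(C(=O)/C=C/c2ccc(Cl)cc2)c2c1C=CC(C)(C)O2` differs from compound 3 at a single place: 4-chlorophenyl in place of furan-2-yl on a double-bonded chain carbon bound to a double-bonded chain carbon. The new group, 4-chlorophenyl, sits on the same double-bonded chain carbon bound to a double-bonded chain carbon.

Among the measured compounds shown here, the one measured step at this place is a step that the two limits leave unreadable from compound 1 to compound 3. It offers neither a size nor a direction to carry over. With only limits to go on, no step beyond the scatter is expected in this assay, and compound 4 is expected to stay in the same region as the others, quite possibly as a limit too. The expected step is a number no higher from compound 3 to compound 4 (the limit leaves the size open). The estimate for compound 4 is 10000 nM. The expected range for compound 4 runs from 3000 nM to 30000 nM.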

Compound 4, half-maximal inhibitory concentration: > 10000 nM
Compound 4: no number, only a limit; the forecaster's own chance of this, stated with the estimate: 70%; the middle value lies on the limit itself.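

In this assay compound 4 gives > 10000 nM as a limit and not a number. Its steps from compound 1, compound 2 and compound 3 cannot be read, as all four values are limits. The compounds shown leave open how strongly any of them inhibits.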